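Aminochalcone and trimethoxy-chalcone pyrazoles: one methoxy removed

The source may hold more compounds than are shown below. What is called first, only, known or untested is meant among the compounds shown, and "the series" means these compounds.

Measured compounds:
compound 1 `COc1cc(-c2cc(/C=C/C(=O)c3ccc(N)cc3)[nH]n2)cc(OC)c1OC` gives 95%
compound 2 `COc1ccc(-c2cc(/C=C/C(=O)c3ccc(N)cc3)[nH]n2)cc1OC` gives 98%
compound 3 `COc1cc(C(=O)/C=C/c2cc(-c3cc(OC)c(OC)c(OC)c3)n[nH]2)cc(OC)c1OC` gives 93%

All three values come from a functional assay on Hs-578T cells (Homo sapiens) for cytotoxicity, read by sulforhodamine B assay, with a stated time of 48 h, tested at 0.01 uM; a lower number here means a stronger effect, a higher number a weaker effect of the compound at the concentration tested. Within this assay compound 1 gives 95% and compound 2 gives 98%; the step of a number 3 percentage points higher from compound 1 to compound 2 (within the scatter) is told as within the scatter, so the two numbers are read as the same size of effect. The change between them is hydrogen in place of methoxy on an aromatic carbon.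

Compound 3 gives 93%. How the core of compound 3 differs from the core of compound 1 is not broken down here; the two differ in more than one place. Against compound 1 the number for compound 3 is lower by a small amount, and against compound 2 by a somewhat larger amount, both within the scatter.

Compound 4 `COc1ccc(-c2cc(/C=C/C(=O)c3cc(OC)c(OC)c(OC)c3)[nH]n2)cc1OC` is not yet measured. It differs from compound 3 by hydrogen in place of methoxy on an aromatic carbon, the same change as from compound 1 to compound 2, at a place described in the same words. Because the earlier step of a number 3 percentage points higher from compound 1 to compound 2 (within the scatter) stayed within the scatter, the step of a number 3 percentage points higher from compound 3 to compound 4 (within the scatter) is expected to be of a similar, small size. Compound 4 is therefore estimated at 96%, with an expected range from 85% to 103%. This expectation rests on one prior pair only and on compound 3 as the starting point.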

Compound 4, a percentage reported as activity, at one concentration (the size of the read-out at that concentration, not a potency): 95%
Beside the measured number, compound 4's estimate is 1 percentage points above it; low and high end bracket the measured number.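

In this assay, hydrogen in place of methoxy on an aromatic carbon gives a number 2 percentage points higher from compound 3 to compound 4 (within the scatter), and set beside the earlier step on the other core, the result is consistent: the same change on two cores in this assay, a number 3 percentage points higher (within the scatter) from compound 1 to compound 2 and a number 2 percentage points higher (within the scatter) from compound 3 to compound 4, 1 percentage points apart, within the scatter of two such steps

On these two cores, then, the change carries over as a step within the scatter, and the two steps cannot be told apart. This does not show that the methoxy is dispensable in general, as it rests on two pairs only, read at a single concentration that gives the size of the read-out and not a potency, so a difference that would appear only at other concentrations, on another core or at another place on the ring would not be seen here.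

The compounds shown leave open whether a group other than hydrogen, such as a hydroxyl, a fluorine or a longer alkoxy chain, would give a step beyond the scatter at this place on the ring. They also leave open what a carboxylic acid or an amide would do in place of the amine of compound 1 and compound 2.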